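This account rests on a few compounds, and the source may have more. Where it says the series, first, only, none or still open, it means among the compounds named here.

Of the compounds shown here, three built on one shared core have so far been measured in a functional assay on A549 cells (Homo sapiens) for antiproliferative activity, read by MTT assay, with a stated time of 24 h; a higher number here means a weaker inhibitor, a lower number a stronger inhibitor. Compound 1 `COc1ccc(-c2cc(C(=O)/C=C/c3ccccc3)nc3cc(-c4ccccc4)nn23)cc1OC` gives 18600 nM. Compound 2 `COc1ccc(-c2cc(/C=C/C(=O)c3ccc(OC)c(OC)c3)nc3cc(-c4ccccc4)nn23)cc1` gives 7400 nM, the second highest of the three numbers; its nearest neighbour is compound 3 `COc1ccc(C(=O)/C=C/c2cc(-c3ccc(OC)c(OC)c3)n3nc(-c4ccccc4)cc3n2)cc1OC`, which gives 3900 nM, and its furthest is compound 1, whose number lies beyond the scatter above it. The only single-place step among these three is a 1.9-fold lower number from compound 2 to compound 3 (0.28 log units; within the scatter), and that step stays within the scatter.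

Compound 4 `COc1ccc(-c2cc(/C=C/C(=O)c3ccccc3)nc3cc(-c4ccccc4)nn23)cc1` is the next member. Relative to compound 2 the change is phenyl in place of 3,4-dimethoxyphenyl on a carbonyl carbon. Among the measured compounds shown here, no measured step removes both methoxy groups from the ring on the carbonyl carbon, so the step from compound 2 to compound 3, which concerns a methoxy on a different ring and is within the scatter, bears on it only loosely. Compounds 1 and 3 differ in more than one place, so their numbers can only be set side by side: compound 1 gives the higher number.

With so little to lean on, compound 4 is expected to give 15000 nM, in a range from 5000 nM to 45000 nM, which means an expected step of a 2.0-fold higher number from compound 2 to compound 4 (0.31 log units; beyond the scatter), a modest rise that may well stay within the scatter.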

Compound 4, half-maximal inhibitory concentration: 8600 nM
Compound 4: the middle estimate sits 1.7-fold (0.24 log units) above what was measured, within the range that was stated.
By their numbers in this assay, from the lowest: compounds 3, 2 and 4 (each within the scatter of the next, the first and the last beyond it); then compound 1.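

Replacing 3,4-dimethoxyphenyl with phenyl on the carbonyl carbon gives a 1.2-fold higher number from compound 2 to compound 4 (0.07 log units; within the scatter) in this assay, so this pair cannot be told apart in this assay. The earlier step concerned a methoxy on a different ring, whereas this one shows that, with compound 2 as the starting point, both methoxy groups on the ring at the carbonyl carbon can be exchanged for hydrogen without the number moving beyond the scatter. No supporting measurement on either compound explains why the two read alike.

The compounds shown carry only phenyl and 3,4-dimethoxyphenyl on this carbonyl carbon, so it remains open whether a ring with a single methoxy, a hydroxy group or a dimethylamino group, or a small chain such as methyl in place of the ring, would keep the number where it is. On these data alone, it is also open whether the same exchange would read alike in compound 3, whose other ring bears one more methoxy than the matching ring in compound 2.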